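The source may hold more compounds than are shown below. What is called first, only, known or untested is meant among the compounds shown, and "the series" means these compounds.

Measured in a functional assay on A549 cells (Homo sapiens) for inhibition, read by sulforhodamine B assay, with a stated time of 72 h; a lower number here means a stronger inhibitor of growth, a higher number a weaker inhibitor of growth:
- Compound 1 `CN1CCN(C(=O)/C=C/c2ccncc2-c2ccc3ccccc3c2)CC1`: > 10000 nM
- Compound 2 `CCOC(=O)/C=C/c1ccncc1-c1ccc2c(cnn2C)c1`: 5030 nM
- Compound 3 `Cn1ncc2cc(-c3cnccc3/C=C/C(=O)O)ccc21`: > 10000 nM

Compound 1 gives > 10000 nM in this assay. This is a limit of the assay and not a number, so compound 1 has no exact position in the series. Compound 3 gives > 10000 nM, which is also a limit. Within the data shown here, compound 2 gives 5030 nM, the only exact value so far.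

Compound 4 `O=C(/C=C/c1ccncc1-c1ccc2ccccc2c1)N1CCOCC1` keeps the core of compound 1 and carries morpholin-4-yl in place of 4-methylpiperazin-1-yl on a carbonyl carbon.

Among the measured compounds shown here, the only measured step is an at least 1.9-fold higher number from compound 2 to compound 3 (0.29 log units; that floor lies within the scatter). It concerns an ester rather than this amide, so it gives no size for the present change. For the measured compounds named here, no measured step bears directly on the change from compound 1 to compound 4, and no step beyond the scatter is expected in this assay.

This expectation rests on compound 1 and on (the limit of > 10000 nM in this assay, at which 2 of the 3 values shown sit). Compound 4 is therefore expected to remain a weak inhibitor of growth and may well be reported only as a limit. The expected change is a step that the limit leaves unreadable from compound 1 to compound 4. For compound 4 the estimated value is 12000 nM, with an expected range from 5000 nM to 30000 nM.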

Compound 4, concentration for 50% growth inhibition: 8410 nM
The estimate for compound 4 lay 1.4-fold (0.15 log units) above the measured number, within the range that was stated.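

With morpholin-4-yl on the carbonyl carbon, compound 4 gives an exact number in this assay, so this position on the core of compound 1 now has a readable amide where compound 1 offered only a limit. The change from 4-methylpiperazin-1-yl to morpholin-4-yl gives an at least 1.1-fold lower number from compound 1 to compound 4 (0.07 log units; that floor lies within the scatter), which fixes no true size for the exchange and leaves open whether it has any effect at all. Only this floor can be read, because compound 1 sits at a limit: the limit of > 10000 nM in this assay, at which 2 of the 4 values shown sit.

As far as these compounds go, how a piperidin-1-yl group, with a ring carbon in place of the morpholine oxygen, or an open-chain dimethylamino group would read on the same carbonyl carbon remains open. Equally open is whether morpholin-4-yl on the carbonyl carbon would read the same on the core of compound 2, for which only an ethyl ester and a carboxylic acid are shown.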